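Changing the tail on a serotonin receptor agonist

The source may hold more compounds than are shown below. What is called first, only, known or untested is meant among the compounds shown, and "the series" means these compounds.

Measured so far:
compound 1 `COC(=O)N1CCN(CCN2CCC(CNC(=O)c3cccc4[nH]c(C(C)C)nc34)CC2)CC1` – 1.59 nM
compound 2 `COC(=O)N(C)CC(O)CN1CCC(CNC(=O)c2cccc3[nH]c(C(C)C)nc23)CC1` – 2 nM

Among the measured compounds shown here, in a functional assay for agonist activity at 5-hydroxytryptamine receptor 4 (Homo sapiens), read by cAMP accumulation (a higher number here means that more compound is needed for the effect, a lower number that less compound is needed), compound 2 gives 2 nM, and compound 1 gives 1.59 nM; the only measured step, a 1.3-fold higher number from compound 1 to compound 2 (0.10 log units; within the scatter), lies within the scatter, so the two stand level. Compound 3 `CC(=O)N1CCC(CN2CCC(CNC(=O)c3cccc4[nH]c(C(C)C)nc34)CC2)CC1` carries 1-acetylpiperidin-4-yl in place of 1-hydroxy-2-((methoxycarbonyl)(methyl)amino)ethyl on a saturated chain carbon bound to an amine nitrogen in a ring. That earlier step also exchanged a tail of matching size at the same place without moving the number, so a similar outcome is expected here: the estimated step of a 1.3-fold higher number from compound 2 to compound 3 (0.10 log units; within the scatter) should stay within the scatter. Compound 3 is therefore expected to give about 2.5 nM, between 0.8 nM and 8 nM.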

Compound 3, half-maximal effective concentration: 1.59 nM
For compound 3 the middle estimate is 1.6-fold (0.20 log units) above the measured one; measured number inside the range.
By their numbers in this assay, from the lowest: compounds 1, 3 and 2 (each within the scatter of the next).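

Compound 3 lacks the methoxycarbonyl group that both earlier compounds carry, yet in this assay the 1-acetylpiperidin-4-yl tail stands level with both (a 1.3-fold lower number from compound 2 to compound 3 (0.10 log units; within the scatter); no change at the digits printed from compound 1 to compound 3 (within the scatter)). On this saturated chain carbon bound to an amine nitrogen in a ring, therefore, neither that group nor the piperazine ring of compound 1 is required for a number this low.

Going by these compounds, whether a tail ending in a carboxylic acid or a free amine, or a plain methyl group, would also hold the number stays open. Nothing available explains why these three tails stand level.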